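Growth inhibition of the series: aryl, saturated ring, fluoroaryl

The compounds below may be only part of what the source reports. "The series", "measured", "known", "first", "only" and "open" are said of these compounds alone.

Compound 1 `CC(C)n1nc(-c2cc(-c3ccccc3)on2)c2c(N)ncnc21`: in an ADME assay on BaF3 cells (Mus musculus) for cytotoxicity, read by MTT assay, with a stated time of 48 h (a lower number here means a stronger inhibitor of growth, a higher number a weaker inhibitor of growth), compound 1 gives > 10000 nM, a limit of the assay.
Compound 2 `CC(C)n1nc(-c2cc(C3CCCCC3)on2)c2c(N)ncnc21`: in this assay compound 2 gives > 10000 nM, also a limit.

Compound 2 thus stands only at the limit of > 10000 nM in this assay, at which 2 of the 2 values shown sit, with no number of its own. The step that the two limits leave unreadable from compound 1 to compound 2 is likewise unreadable, since both ends are limits. Compound 3 `CC(C)n1nc(-c2cc(-c3ccc(F)cc3)on2)c2c(N)ncnc21` differs from compound 2 by 4-fluorophenyl in place of cyclohexyl on an aromatic carbon. Only the unreadable step bears on this change, so no direction or size can be drawn from it. Compound 3 is therefore expected to remain at the limit, estimated at 15000 nM within 7000 nM to 50000 nM. The expected step that the limit leaves unreadable from compound 2 to compound 3 is nominal only.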

Compound 3, concentration for 50% growth inhibition: > 10000 nM
Compound 3: a limit, no number; the forecaster's own chance of this, stated with the estimate: 85%; the middle value does not contradict the limit.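

Compound 3, like compound 1 and compound 2, gives only a limit, so no step among them can be read: the limit of > 10000 nM in this assay, at which 3 of the 3 values shown sit.

The compounds shown leave open whether phenyl, cyclohexyl or 4-fluorophenyl differ at all in this assay.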